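Dimethoxy analogue of a trimethoxy pyrazolyl chalcone

The source may report more compounds than this note shows. Statements on the series, on what has been measured and on what is new or still open speak of the compounds shown alone.

Compound 1, `COc1ccc(-c2cc(/C=C/C(=O)c3ccc(N)cc3)[nH]n2)cc1`: in a functional assay on SF-295 cells (Homo sapiens) for inhibition, read by sulforhodamine B assay, with a stated time of 48 h (a higher number here means a weaker inhibitor of growth, a lower number a stronger inhibitor of growth), compound 1 gives 13100 nM.
Compound 2, `COc1cc(-c2cc(/C=C/C(=O)c3ccc(N)cc3)[nH]n2)cc(OC)c1OC`: in this assay compound 2 gives 10900 nM.

Compound 2 holds the lower of the two numbers, and its nearest neighbour is compound 1, which sits within the scatter of it, so the two are not told apart. The next compound, compound 3, `COc1ccc(-c2cc(/C=C/C(=O)c3ccc(N)cc3)[nH]n2)cc1OC`, differs from compound 2 in one place: hydrogen in place of methoxy on an aromatic carbon. The change is a hydrogen in place of a methoxy group. Between compound 1, which carries one methoxy group, and compound 2, which carries three, the numbers in this assay barely move, so removing one of the three is expected to change little. The step of a 1.1-fold higher number from compound 2 to compound 3 (0.04 log units; within the scatter) is expected to stay within the scatter. Compound 3 is estimated at 12000 nM in this assay, with a range from 5000 nM to 28000 nM.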

Compound 3, concentration for total growth inhibition: 15200 nM
Compound 3: middle estimate off by 1.3-fold (0.10 log units), on the low side, and the stated range covers the measured number.
By their numbers in this assay, from the lowest: compounds 2, 1 and 3 (each within the scatter of the next).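

In this assay, the exchange can now be read from both sides on the same kind of carbon, meta to a large group and ortho to a methoxy group: hydrogen in place of methoxy gives a 1.4-fold higher number from compound 2 to compound 3 (0.14 log units; within the scatter), and methoxy in place of hydrogen gives a 1.2-fold higher number from compound 1 to compound 3 (0.06 log units; within the scatter). Neither step leaves the scatter, so methoxy and hydrogen at this place are not told apart in this assay, whether the ring carries one other methoxy group or two. Nothing shown offers an explanation for this result.

From the compounds shown here alone, it remains open whether a hydroxyl group, a fluorine atom or an amine on this carbon would give a step beyond the scatter. Going by these compounds, it also remains open whether replacing the amino group of the shared core with a nitro group or an acetamide would do so.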